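The compounds below may be only part of what the source reports. "The series", "measured", "known", "first", "only" and "open" are said of these compounds alone.

Measured compounds:
compound 1 `O=C(NCc1cc(Cl)ccc1-n1cnnn1)[C@@H]1C[C@@H]2C[C@@H]2N1C(=O)[C@H](O)Cn1cccn1` — 0.45 10^-6 cm/s
compound 2 `O=C(NCc1cc(Cl)ccc1-n1cnnn1)[C@@H]1CC=NN1C(=O)[C@H](O)c1ccccc1F` — 8.9 10^-6 cm/s

In an ADME assay on Caco-2 cells (Homo sapiens) for permeability, read by LC-MS, in the apical to basolateral direction, with a stated time of 60 min, at pH 6.5 (on this read-out lower numbers stand for lower permeability and higher numbers for higher permeability), compound 1 gives 0.45 10^-6 cm/s, the lower of the two numbers; compound 2 gives 8.9 10^-6 cm/s, a gap beyond the usual scatter. Compound 3 `COC(C)(C)[C@@H](O)C(=O)N1[C@H](C(=O)NCc2cc(Cl)ccc2-n2cnnn2)C[C@@H]2C[C@@H]21` has not yet been measured in this assay. It differs from compound 1 in one place: 1-methoxy-1-methylethyl in place of (1H-pyrazol-1-yl)methyl on a saturated chain carbon bound to a carbonyl carbon and an oxygen on a saturated carbon. Among the compounds with values here, no measured pair shows what this change does here. Compound 3 is expected to give a somewhat higher number than compound 1, a modest step of a 3.3-fold higher number from compound 1 to compound 3 (0.52 log units; beyond the scatter). The estimate for compound 3 in this assay is 1.5 10^-6 cm/s, within a range from 0.5 10^-6 cm/s to 4.5 10^-6 cm/s.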

Compound 3, apparent permeability: 16 10^-6 cm/s
The estimate for compound 3 lay 11-fold (1.03 log units) below the measured number; the whole stated range lies below it.
By their numbers in this assay, from the lowest: compound 1; then compounds 2 and 3 (each within the scatter of the next).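

In this assay, the place on a saturated chain carbon bound to a carbonyl carbon and an oxygen proves highly sensitive: 1-methoxy-1-methylethyl in place of (1H-pyrazol-1-yl)methyl gives a 36-fold higher number from compound 1 to compound 3 (1.55 log units; beyond the scatter), with the rest of the structure unchanged. This is the only pair shown that differs in one place, so it gives the first direct reading of a change at this position. No measurement at hand gives a cause for the step. As far as these compounds go, whether a tert-butyl group or an amine at this place would give a similar number remains open. So does whether the same change would have a similar effect on the core of compound 2.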